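Ethyl for methyl on the shared core

A few compounds are considered here, and "the series" means these few. Any claim that something is new, unique, unknown or untested is made for them only; others in the source may bear on it.

Measured compounds:
compound 1 `Cc1cc(F)c(S(C)(=O)=O)cc1C(=O)N=C(N)N`: 44 nM
compound 2 `Cc1cc(Br)c(S(C)(=O)=O)cc1C(=O)N=C(N)N`: 12 nM
compound 3 `Cc1cc(C)c(S(C)(=O)=O)cc1C(=O)N=C(N)N`: 11 nM

In a functional assay for inhibition of sodium/hydrogen exchanger (Oryctolagus cuniculus) (on this read-out lower numbers stand for stronger inhibition and higher numbers for weaker inhibition), compound 3 gives the lowest number of the three, though its gap to compound 2 is within the scatter; only compound 1 stands clearly apart, as a 4.0-fold lower number from compound 1 to compound 3 (0.60 log units; beyond the scatter) and a 3.7-fold lower number from compound 1 to compound 2 (0.56 log units; beyond the scatter) show, while a 1.1-fold lower number from compound 2 to compound 3 (0.04 log units; within the scatter) is within the scatter. Compound 4 `CCc1cc(C)c(C(=O)N=C(N)N)cc1S(C)(=O)=O` differs from compound 3 by methyl in place of hydrogen on a saturated chain carbon bound to an aromatic carbon. For the measured compounds named here, none of the measured steps touches this chain; they all concern exchanges on an aromatic carbon, and those that involve bromo and methyl are small. The step of a 1.4-fold higher number from compound 3 to compound 4 (0.13 log units; within the scatter) is therefore expected to remain within the scatter. Compound 4 is estimated at 15 nM, with a range of 6 nM to 40 nM.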

Compound 4, half-maximal inhibitory concentration: 4.8 nM
Compound 4: the middle estimate sits 3.1-fold (0.49 log units) above what was measured; measured number below the stated range.
By their numbers in this assay, from the lowest: compound 4; then compounds 3 and 2 (each within the scatter of the next); then compound 1.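

In this assay, for the compounds shown here, the saturated chain proves to be a place where a single added methyl counts: methyl to ethyl gives a 2.3-fold lower number from compound 3 to compound 4 (0.36 log units; beyond the scatter), whereas the earlier compounds showed changes only on an aromatic carbon. The ethyl compound also stands clear of the bromo and fluoro compounds, with a 2.5-fold lower number from compound 2 to compound 4 (0.40 log units; beyond the scatter) and a 9.2-fold lower number from compound 1 to compound 4 (0.96 log units; beyond the scatter). No measurement shown here accounts for this difference. From the compounds shown here alone, whether a propyl group or a longer chain in this place would lower the number further or raise it again remains open.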